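A few compounds are considered here, and "the series" means these few. Any claim that something is new, unique, unknown or untested is made for them only; others in the source may bear on it.

Measured in a functional assay on L1210 cells (Mus musculus) for inhibition; on this read-out lower numbers stand for stronger inhibition and higher numbers for weaker inhibition:
compound 1 `CC(C)CN(CC(=O)N(CC(C)C)NC(=O)OCc1ccccc1)NC(=O)CBr`: 6500 nM
compound 2 `CC(C)CN(NC(=O)OCc1ccccc1)C(=O)CN(Cc1ccccc1)NC(=O)CBr`: 1300 nM

Of these two numbers, compound 2 has the lower, 1300 nM. Compound 3 `O=C(CN(Cc1ccccc1)NC(=O)CBr)NNC(=O)OCc1ccccc1` differs from it by hydrogen in place of isobutyl on an amide-type nitrogen. Among the measured compounds shown here, the only measured step, a 5.0-fold lower number from compound 1 to compound 2 (0.70 log units; beyond the scatter), was modest and lies at a different place, so it bears only indirectly. For the measured compounds named here, no measured step covers this change. A similarly modest rise in this assay is expected, with the direction uncertain. The expected change is a 1.9-fold higher number from compound 2 to compound 3 (0.28 log units; within the scatter). Compound 3 is estimated at 2500 nM, within a range from 800 nM to 8000 nM.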

Compound 3, half-maximal inhibitory concentration: 600 nM
Estimate against measurement, compound 3: 4.2-fold (0.62 log units) above; measured number outside the range, below it.
By their numbers in this assay, from the lowest: compound 3; then compound 2; then compound 1.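

In this assay, hydrogen in place of isobutyl on the amide-type nitrogen brings a 2.2-fold lower number from compound 2 to compound 3 (0.34 log units; beyond the scatter), so inhibition in these cells does not depend on this isobutyl and is stronger without it. Among the compounds shown here, this is the first reading at this position, as the earlier step lay at a different place. Nothing available here explains the change. On these data alone, it remains open whether a methyl group or a longer chain on this nitrogen would give a higher or lower number than hydrogen. As far as these compounds go, the same exchange in compound 1 also remains open.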